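A few compounds are considered here, and "the series" means these few. Any claim that something is new, unique, unknown or untested is made for them only; others in the source may bear on it.

Measured in an in vitro ADME assay on microsomes from liver (Mus musculus) for pharmacokinetics, read by LC-MS, with a stated time of 10 min, tested at 1 uM; on this read-out higher numbers stand for fast clearance and lower numbers for slow clearance:
- compound 1 `COc1cccc(NC(=O)[C@H]2CN(C)C[C@@H]2c2ccc(/C=C/C(=O)Nc3ccccc3N)cc2)c1`: 65 mL/min/kg
- compound 2 `Cc1cc(NC(=O)[C@H]2CN(C)C[C@@H]2c2ccc(/C=C/C(=O)Nc3ccccc3N)cc2)ccc1F`: 62 mL/min/kg
- compound 3 `CN1C[C@H](C(=O)Nc2ccc(F)cc2F)[C@@H](c2ccc(/C=C/C(=O)Nc3ccccc3N)cc2)C1`: 27 mL/min/kg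

Compound 3, at 27 mL/min/kg, has the lowest number of the three. Compound 4 `CN1C[C@H](C(=O)Nc2cccnc2)[C@@H](c2ccc(/C=C/C(=O)Nc3ccccc3N)cc2)C1` differs from it in one place: pyridin-3-yl in place of 2,4-difluorophenyl on an amide-type nitrogen. In short, pyridin-3-yl replaces 2,4-difluorophenyl on an amide-type nitrogen. All three measured steps are swaps at this same place. Two were modest, a 2.4-fold lower number from compound 1 to compound 3 (0.38 log units; beyond the scatter) and a 2.3-fold lower number from compound 2 to compound 3 (0.36 log units; beyond the scatter), while a 1.0-fold lower number from compound 1 to compound 2 (0.02 log units; within the scatter) stayed within the scatter. Among the compounds with values here, no measured compound carries pyridin-3-yl, so the direction is uncertain. Since the number for compound 3 is already the lowest, a modest rise in this assay is expected, an estimated 1.3-fold higher number from compound 3 to compound 4 (0.12 log units; within the scatter). The estimated clearance of compound 4 is 36 mL/min/kg, with an expected range of 16 mL/min/kg to 75 mL/min/kg.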

Compound 4, clearance: 41 mL/min/kg
Compound 4: the middle estimate sits 1.1-fold (0.06 log units) below what was measured; low and high end bracket the measured number.
By their numbers in this assay, from the lowest: compounds 3, 4, 2 and 1 (each within the scatter of the next, the first and the last beyond it).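

In this assay the pyridin-3-yl ring, the only ring on this amide-type nitrogen with a hetero atom, gives a 1.5-fold higher number from compound 3 to compound 4 (0.18 log units; within the scatter) and a 1.5-fold lower number from compound 2 to compound 4 (0.18 log units; within the scatter) and a 1.6-fold lower number from compound 1 to compound 4 (0.20 log units; within the scatter) and all three steps lie within the scatter. Compound 4 therefore cannot be told apart from any of the other compounds, even though compound 3 stands apart from compound 1 and compound 2. No evidence is available to explain this result.

Still open, from the compounds shown here alone, is whether an amine or a carboxylic acid on this ring would take the clearance beyond the scatter. The same question applies to a longer chain placed between the amide-type nitrogen and the ring.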